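Solubility of Two Quinoline-Like Analogues and a Branched Isomer

The compounds below may be only part of what the source reports. "The series", "measured", "known", "first", "only" and "open" are said of these compounds alone.

Measured compounds:
- compound 1, `Cc1cc(C)cc(Cc2ccc3c(NCCCNCc4ccco4)ccnc3c2)c1`: 4200 nM
- compound 2, `CC(C)CCc1ccc2c(NCCCNCc3ccco3)ccnc2c1`: 4200 nM

In a physicochemical assay for solubility, with a stated time of 18 h, at pH 7.4 (on this read-out lower numbers stand for lower solubility and higher numbers for higher solubility), compound 1 gives 4200 nM and compound 2 gives 4200 nM. The one measured step, no change at the digits printed from compound 1 to compound 2 (within the scatter), was no change at the digits shown, the isobutyl standing in place of the 3,5-dimethylphenyl on a saturated chain carbon bound to an aromatic carbon. Compound 2 therefore stands level with compound 1 on this read-out.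

Compound 3, `CCC(CC)c1ccc2c(NCCCNCc3ccco3)ccnc2c1`, has the same atoms as compound 2 joined differently: pentan-3-yl in place of isopentyl on an aromatic carbon. Among the measured compounds shown here, no measured step touches a rearrangement of this kind; the only step on record, from a larger aromatic group to a short chain, moved nothing. On that basis a step of no size beyond the scatter is expected, no change at the digits printed from compound 2 to compound 3 (within the scatter). Compound 3 is accordingly estimated at 4200 nM, within a range of 2100 nM to 8400 nM in this assay.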

Compound 3, solubility: 4200 nM
Compound 3: middle estimate and measured number agree at the digits printed; measured number inside the range.
By their numbers in this assay, from the lowest: compounds 1, 2 and 3 (each within the scatter of the next).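

In this assay the isomer shows something the earlier pair could not: when the same atoms are joined differently on this aromatic carbon, the result is no change at the digits printed from compound 2 to compound 3 (within the scatter) for pentan-3-yl in place of isopentyl. The branched group also reads level with the larger aromatic group, with no change at the digits printed from compound 1 to compound 3 (within the scatter) for pentan-3-yl in place of 3,5-dimethylbenzyl, so the three groups at this position show no spread at the digits printed. Nothing available explains this absence of a difference.

From the compounds shown here alone, whether an amine, a carboxylic acid or a hydroxyl group at this position would read differently remains open. So does the outcome for a much shorter group such as methyl, or for a longer chain such as octyl.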